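The compounds below may be only part of what the source reports. "The series", "measured", "known", "first", "only" and "open" are said of these compounds alone.

Measured so far:

Compound 1, `CCN(Cc1ccncc1)C(=S)SCc1ccc(C(=O)Nc2ccccc2N)cc1`: 86.2% 
Compound 2, `Nc1ccccc1NC(=O)c1ccc(CSC(=S)N2CCCc3ccccc32)cc1`: 81.5% 

In a functional assay on A-375 cells (Homo sapiens) for antiproliferative activity, read by CCK-8 assay, with a stated time of 72 h, tested at 8 uM (a lower number here means a weaker effect, a higher number a stronger effect of the compound at the concentration tested), compound 2 stands lowest of the two numbers; its nearest neighbour is compound 1, and the step of a number 4.7 percentage points lower from compound 1 to compound 2 (within the scatter) lies within the scatter, so the two cannot be ordered. Compound 3, `Nc1ccccc1NC(=O)c1ccc(CSC(=S)N2CCCC2)cc1`, has not been measured. It differs from compound 2 in one place: pyrrolidin-1-yl in place of 1,2,3,4-tetrahydroquinolin-1-yl on a thiocarbonyl carbon. Within the data shown here, the only measured step that touches the same place is the one from compound 1 to compound 2, which also swapped the amine on the thiocarbonyl carbon, and it was a number 4.7 percentage points lower from compound 1 to compound 2 (within the scatter), within the scatter. On that basis a step of similar size is expected for a number 3.5 percentage points lower from compound 2 to compound 3 (within the scatter), with no direction that can be trusted beyond the scatter. Compound 3 is therefore estimated at 78%, within the range 60% to 92%.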

Compound 3, a percentage reported as inhibition, at one concentration (the size of the read-out at that concentration, not a potency): 89.5%
Beside the measured number, compound 3's estimate is 11.5 percentage points below it, and the stated range covers the measured number.
By their numbers in this assay, from the lowest: compounds 2, 1 and 3 (each within the scatter of the next).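

In this assay, the swap at the thiocarbonyl carbon gave a number 8 percentage points higher from compound 2 to compound 3 (within the scatter), and the swap from the open amine gave a number 3.3 percentage points higher from compound 1 to compound 3 (within the scatter). The position therefore accepted a group going from 10 heavy atoms to 5 and losing its six-membered aromatic ring, with no difference beyond the scatter, so pyrrolidin-1-yl, 1,2,3,4-tetrahydroquinolin-1-yl and ethyl((pyridin-4-yl)methyl)amino cannot be ordered at this concentration. No supporting information is available to account for this result.

A single concentration leaves open whether these three compounds would separate in potency at lower concentrations. On these data alone, it also remains open whether a morpholine, a piperazine or a small open amine such as dimethylamino on the same thiocarbonyl carbon would give a step beyond the scatter.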